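Methoxy for methyl on the aryl ring: cytotoxicity notes

The compounds below may be only part of what the source reports. "The series", "measured", "known", "first", "only" and "open" are said of these compounds alone.

Values below come from an ADME assay on Huh7.5.1 cells (Homo sapiens) for cytotoxicity, read by ATP content, with a stated time of 48 h; on this read-out higher numbers stand for lower toxicity in this test and lower numbers for higher toxicity in this test.

compound 1 `Cc1cccc(F)c1-c1nc(CN2CCC(C(=O)NCCCN3C[C@H](C)C[C@H](C)C3)CC2)c(C)o1` gives 13000 nM
compound 2 `COc1cccc(F)c1-c1nc(CN2CCC(C(=O)NCCCN3C[C@H](C)C[C@H](C)C3)CC2)c(C)o1` gives 37000 nM
compound 3 `Cc1cccc(C)c1-c1nc(CN2CCC(C(=O)NCCCN3C[C@H](C)C[C@H](C)C3)CC2)c(C)o1` gives 21000 nM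

Within this small set, one change has been measured once: methoxy in place of methyl on an aromatic carbon, which in this assay reads a 2.8-fold higher number from compound 1 to compound 2 (0.45 log units; beyond the scatter). The step between compound 1 and compound 3 is a 1.6-fold higher number from compound 1 to compound 3 (0.21 log units; within the scatter), and between compound 2 and compound 3 it is a 1.8-fold lower number from compound 2 to compound 3 (0.25 log units; within the scatter); neither of these two separates the compounds.

Compound 4 `COc1cccc(C)c1-c1nc(CN2CCC(C(=O)NCCCN3C[C@H](C)C[C@H](C)C3)CC2)c(C)o1` is not yet measured. It differs from compound 3 by methoxy in place of methyl on an aromatic carbon. The two cores differ by methyl in place of fluoro on an aromatic carbon; the surroundings of the change read "meta to a fluoro group" for the measured pair and "meta to a methyl group" for the new pair, so this is the same kind of change rather than the same one.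

For the measured compounds named here, for this assay the expected step from compound 3 to compound 4 is a 2.4-fold higher number from compound 3 to compound 4 (0.38 log units; beyond the scatter), resting on the single measured step of a 2.8-fold higher number from compound 1 to compound 2 (0.45 log units; beyond the scatter) and tempered by the different neighbouring group. Compound 4 is thus estimated at 50000 nM, with a range of 25000 nM to 100000 nM.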

Compound 4, half-maximal cytotoxic concentration in the Huh7.5.1 assay: 16700 nM
Compound 4: middle estimate off by 3.0-fold (0.48 log units), on the high side; the measured number lies below the stated range.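

In the Huh7.5.1 assay the new step reads a 1.3-fold lower number from compound 3 to compound 4 (0.10 log units; within the scatter), and methoxy in place of methyl does not carry unchanged from the core of compound 1 to the core of compound 3: the same change on two cores in the Huh7.5.1 assay, a 2.8-fold higher number (0.45 log units; beyond the scatter) from compound 1 to compound 2 and a 1.3-fold lower number (0.10 log units; within the scatter) from compound 3 to compound 4, 3.6-fold (0.55 log units) apart, beyond the scatter of two such steps

Methyl in place of fluoro reads a 2.2-fold lower number from compound 2 to compound 4 (0.35 log units; beyond the scatter), and it also differs between the two cores: the same change on two cores in the Huh7.5.1 assay, a 1.6-fold higher number (0.21 log units; within the scatter) from compound 1 to compound 3 and a 2.2-fold lower number (0.35 log units; beyond the scatter) from compound 2 to compound 4, 3.6-fold (0.55 log units) apart, beyond the scatter of two such steps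

Methoxy in place of fluoro reads a 1.3-fold higher number from compound 1 to compound 4 (0.11 log units; within the scatter); all of these steps come from one set of four compounds, so the gap is a single observation that shows the step failing to transfer here, but not why it fails or how general this is across the series.

In a physicochemical assay for solubility, in phosphate buffer, measured as kinetic solubility, at pH 7.4 (on this read-out higher numbers stand for higher solubility and lower numbers for lower solubility), compound 3 gives 55.9 ug/mL. In the physicochemical assay compound 4 gives > 73 ug/mL, a limit of the assay and not a number. Going by these compounds, the distance between compound 3 and compound 4 stays open. On these data alone, whether the methoxy step would hold with a chloro group or a nitrile in place of the fluoro or methyl on the aromatic ring also stays open.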